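Swapping Dimethylamino for Amino on a Second Core

The source may hold more compounds than are shown below. What is called first, only, known or untested is meant among the compounds shown, and "the series" means these compounds.

Compound 2 `COc1ccc(C(=O)c2ccc(OC)c3c2C=CC(C)(C)O3)c(NC(=O)CN(C)C)c1` and compound 1 `COc1ccc(C(=O)c2ccc(OC)c3c2C=CC(C)(C)O3)c(NC(=O)CN)c1` share one core and differ by amino in place of dimethylamino on a saturated chain carbon bound to a carbonyl carbon. In a functional assay on A549 cells (Homo sapiens) for antiproliferative activity, read by MTT assay, with a stated time of 48 h (on this read-out lower numbers stand for stronger inhibition and higher numbers for weaker inhibition), compound 2 gives 1850 nM, while compound 1 gives 420 nM; that step is a 4.4-fold lower number from compound 2 to compound 1 (0.64 log units; beyond the scatter). Compound 3 `COc1ccc(C(=O)c2cc(OC)c(OC)c(OC)c2)c(NC(=O)CN(C)C)c1` carries the dimethylamino group on a different core; the difference between the two cores is not broken down here. In this assay compound 3 gives 590 nM. Compound 4 `COc1ccc(C(=O)c2cc(OC)c(OC)c(OC)c2)c(NC(=O)CN)c1` is made from compound 3 by the same change, (amino in place of dimethylamino on a saturated chain carbon bound to a carbonyl carbon), at the same place. For the measured compounds named here, for compound 4 the expected step is a 3.9-fold lower number from compound 3 to compound 4 (0.59 log units; beyond the scatter), close in size to the earlier one, because the earlier step of a 4.4-fold lower number from compound 2 to compound 1 (0.64 log units; beyond the scatter) is the only guide available and the two cores are not the same. Compound 4 is therefore expected to give 150 nM, estimated between 60 nM and 400 nM.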

Compound 4, half-maximal inhibitory concentration: 220 nM
Compound 4: the middle estimate sits 1.5-fold (0.17 log units) below what was measured; low and high end bracket the measured number.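

In this assay the swap to amino on the core of compound 3 gives a 2.7-fold lower number from compound 3 to compound 4 (0.43 log units; beyond the scatter) and so lowers the number on this core too. Set beside the earlier step, the size of the change holds up on the second core: the same change on two cores in this assay, a 4.4-fold lower number (0.64 log units; beyond the scatter) from compound 2 to compound 1 and a 2.7-fold lower number (0.43 log units; beyond the scatter) from compound 3 to compound 4, 1.6-fold (0.22 log units) apart, within the scatter of two such steps

This shows that the change carried over from one core to the other in this single cell assay, but two cores are too few to promise the same on a third, and the numbers do not explain why amino gives the lower value. The compounds shown leave open how a methylamino or diethylamino group would behave at this place on a saturated chain carbon bound to a carbonyl carbon. They also leave open what a longer chain carrying the amino group would do.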